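Styryl hydrazone on a shared oxadiazole-thioacetyl core

The compounds below may be only part of what the source reports. "The series", "measured", "known", "first", "only" and "open" are said of these compounds alone.

Three hydrazones built on one shared core have been examined in an ADME assay on NIH3T3 cells (Mus musculus) for cytotoxicity, read by MTT assay, with a stated time of 24 h; on this read-out lower numbers stand for stronger inhibition and higher numbers for weaker inhibition. Compound 1 `O=C(CSc1nnc(-c2ccncc2)o1)N/N=C/c1ccc(F)cc1` gives 170000 nM in this assay. Compound 2 `Cc1ccc(/C=N/NC(=O)CSc2nnc(-c3ccncc3)o2)cc1` gives 185000 nM, and compound 3 `O=C(CSc1nnc(-c2ccncc2)o1)N/N=C/c1cc(Cl)ccc1O` gives 166000 nM. Compound 1 stands second highest of these three numbers, with compound 3 nearest and compound 2 furthest, and every gap among them is within the scatter: a 1.1-fold higher number from compound 1 to compound 2 (0.04 log units; within the scatter), a 1.0-fold lower number from compound 1 to compound 3 (0.01 log units; within the scatter), a 1.1-fold lower number from compound 2 to compound 3 (0.05 log units; within the scatter). Compound 4 `O=C(CSc1nnc(-c2ccncc2)o1)N/N=C/C=C/c1ccccc1` has not yet been measured in this assay. It differs from compound 1 in one place: 2-phenylethenyl in place of 4-fluorophenyl on a carbon with a double bond to nitrogen. Among the compounds with values here, no measured step swaps in a 2-phenylethenyl group, but all three measured steps alter the same aromatic group on the carbon double-bonded to nitrogen, and none of them moves the number beyond the scatter. The expected step is therefore no change at the digits printed from compound 1 to compound 4 (within the scatter), nothing beyond the scatter. For compound 4 the estimated value in this assay is 170000 nM, expected to fall between 85000 nM and 340000 nM.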

Compound 4, half-maximal inhibitory concentration: 160000 nM
Compound 4: the middle estimate sits 1.1-fold (0.03 log units) above what was measured, and the stated range covers the measured number.
By their numbers in this assay, from the lowest: compounds 4, 3, 1 and 2 (each within the scatter of the next).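

In this assay, within the data shown here, the earlier steps had only exchanged one aromatic group for another directly on the carbon with a double bond to nitrogen, whereas 2-phenylethenyl also brings 1 double bond outside aromatic rings. That change stays within the scatter against each of the other three compounds (a 1.1-fold lower number from compound 1 to compound 4 (0.03 log units; within the scatter); a 1.0-fold lower number from compound 3 to compound 4 (0.02 log units; within the scatter); a 1.2-fold lower number from compound 2 to compound 4 (0.06 log units; within the scatter)), so this position shows no measurable response to this group as well as to the aromatic groups. Nothing shown here bears on why the numbers stay together.

Going by these compounds, all four groups at this position carry a six-membered aromatic ring of carbon only, so what an amine, a carboxylic acid or a longer alkyl chain would do there remains open. On these data alone, the shared core is the same throughout, and the effect of any change to it is open too.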